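Swapping Chloro for Bromo on the Sulfonamide Ring

A few compounds are considered here, and "the series" means these few. Any claim that something is new, unique, unknown or untested is made for them only; others in the source may bear on it.

Measured compounds and their values:
Compound 1, `Cc1ncc([N+](=O)[O-])n1CC(=O)NS(=O)(=O)c1ccc(Cl)cc1`, 2.47 ug/mL
Compound 2, `O=C(Cc1ccc(F)cc1)NS(=O)(=O)c1ccc(Cl)cc1`, 6.28 ug/mL
Compound 3, `O=C(Cc1ccc(F)cc1)NS(=O)(=O)c1ccc(F)cc1`, 5.64 ug/mL

All three compounds were tested in a functional assay on A549 cells (Homo sapiens) for antiproliferative activity, read by MTT assay, with a stated time of 48 h; a lower number here means a stronger inhibitor, a higher number a weaker inhibitor. Compound 1 gives the lowest number of the three; its gap to compound 3 and its gap to compound 2 each lie beyond the scatter, so compound 1 is the strongest inhibitor among the measured set. Compounds 2 and 3 share a core that differs from that of compound 1, and their values lie close together.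

Compound 4, `Cc1ncc([N+](=O)[O-])n1CC(=O)NS(=O)(=O)c1ccc(Br)cc1`, differs from compound 1 in one place: bromo in place of chloro on an aromatic carbon. Going by the values given here, no measured step swaps chloro for bromo. Among the compounds with values here, the only measured step that changes a halogen on that ring is a 1.1-fold lower number from compound 2 to compound 3 (0.05 log units; within the scatter), which stays within the scatter. On this basis, the change from compound 1 to compound 4 is expected to give no step beyond the scatter in this assay, in either direction, so that a 1.0-fold lower number from compound 1 to compound 4 (0.01 log units; within the scatter) is the expected step. Compound 4 is therefore estimated at 2.4 ug/mL, with a range from 1.2 ug/mL to 4.8 ug/mL.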

Compound 4, half-maximal inhibitory concentration: 3.03 ug/mL
The estimate for compound 4 lay 1.3-fold (0.10 log units) below the measured number, within the range that was stated.
By their numbers in this assay, from the lowest: compounds 1, 4, 3 and 2 (each within the scatter of the next, the first and the last beyond it).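

In this assay, the ring position that carries the halogen now has a swap on the core of compound 1, and a 1.2-fold higher number from compound 1 to compound 4 (0.09 log units; within the scatter) stays within the usual scatter. Going by these compounds alone, until now, the only halogen change on this ring was fluoro in place of chloro on the other core, so this result adds a second halogen and a second core to that picture: across these two pairs, the change of halogen does not move the number beyond the scatter. No measurement at hand explains why chloro and bromo read alike here.

The compounds shown carry only halogens at this position, so it remains open how an amine, a carboxylic acid or a methoxy group there would read. From the compounds shown here alone, it also remains open whether the ring can go without any group at that position, with plain hydrogen in place of the halogen.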